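The source may report more compounds than this note shows. Statements on the series, on what has been measured and on what is new or still open speak of the compounds shown alone.

Compound 1, `CCCCCNc1nc(NCc2ccco2)c2ccccc2n1`: "not determined" (no result reported) in a functional assay on HT-29 cells (Homo sapiens) for cytotoxicity, read by MTT assay, with a stated time of 2 days, tested at 10 uM; a lower number here means less inhibition, a higher number more inhibition at the concentration tested (going by the name of the read-out).
Compound 2, `CCCCNc1nc(NCc2ccco2)c2cc(F)ccc2n1`: 88.1% in this assay.
Compound 3, `CCCCNc1nc(NCc2ccco2)c2cccc(F)c2n1`: "not determined" (no result reported) in this assay.

Within the data shown here, compound 3 therefore has no number to stand on; the only number in the set comes from compound 2, which shares the core and the butyl chain and differs only in where its fluoro sits. Compound 4, `CCCCNc1nc(NCc2ccco2)c2ccccc2n1`, is the same core without that fluoro: hydrogen in place of fluoro on an aromatic carbon. Among the measured compounds shown here, with no measured step to lean on, the change from compound 3 to compound 4 is expected to be small in this assay, with no clear direction beyond the scatter. Compound 4 is estimated at 75%, within a range of 40% to 95%.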

Compound 4, a percentage reported as inhibition, at one concentration (the size of the read-out at that concentration, not a potency): 92.3%
For compound 4 the middle estimate is 17.3 percentage points below the measured one; low and high end bracket the measured number.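

Hydrogen in place of fluoro gives a number 4.2 percentage points higher from compound 2 to compound 4 (within the scatter) in this assay, so at the one concentration tested, compound 2 and compound 4 cannot be told apart. The fluoro of compound 2 is therefore not needed for this level of inhibition, although a single-concentration read-out says nothing about potency. No measurement shown explains this result.

Going by these compounds, the step between compound 3 and compound 4 cannot be read, so the effect of the fluoro in compound 3 stays open. On these data alone, whether a methoxy group or an amine on that aromatic carbon would give a similar read-out also stays open.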